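Compound 4: another limit expected in the cytotoxicity test

A few compounds are considered here, and "the series" means these few. Any claim that something is new, unique, unknown or untested is made for them only; others in the source may bear on it.

Compound 3 `CCc1ccc(-c2ccc3ncc(-c4noc(CC)n4)cc3c2)cc1` was examined in a functional assay on RD cells (Homo sapiens) for inhibition, read by luminescence and ATP content, with a stated time of 72 h; on this read-out lower numbers stand for higher toxicity in this test and higher numbers for lower toxicity in this test. In this assay compound 3 gives > 22200 nM, which is a limit of the assay and not a number. Its two measured neighbours also end at limits. Compound 1 `CCc1nc(-c2cnc3ccc(-c4ccc(N)nc4)cc3c2)no1` gives > 66700 nM, a limit of the assay. Compound 2 `CCCc1ccc(-c2ccc3ncc(-c4noc(CC)n4)cc3c2)cc1` gives > 7400 nM, likewise a limit of the assay. The step that the two limits leave unreadable from compound 1 to compound 3 therefore cannot be read, and the same holds for a step that the two limits leave unreadable from compound 2 to compound 3. Compound 3 thus stands among three compounds whose half-maximal cytotoxic concentrations were all reported only as limits, as recorded in the limit of > 22200 nM in this assay, at which 1 of the 3 values shown sits, the limit of > 66700 nM in this assay, at which 1 of the 3 values shown sits, and (the limit of > 7400 nM in this assay, at which 1 of the 3 values shown sits).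

Compound 4 `CCc1nc(-c2cnc3ccc(-c4ccc(C)cc4)cc3c2)no1` differs from compound 3 by hydrogen in place of methyl on a saturated chain carbon bound to an aromatic carbon. The change from compound 2 to compound 3 is of the same kind, hydrogen in place of methyl on the chain, and its size could not be read; the change from compound 1 to compound 3 exchanges the whole aryl group and is equally unreadable. Within the data shown here, no measured step therefore points to a shift beyond the scatter, and the step that the limit leaves unreadable from compound 3 to compound 4 is expected to be of no readable size. Compound 4 is estimated at 40000 nM, between 10000 nM and 150000 nM, most likely reported again only as a limit.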

Compound 4, half-maximal cytotoxic concentration: > 7400 nM
Compound 4: no number, only a limit (the forecaster's own chance of this, stated with the estimate: 85%); the middle value lies beyond the limit too.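

Compound 4 gives > 7400 nM in this assay, which is a limit of the assay and not a number, and the steps linking compound 4 to compound 1, compound 2 and compound 3 cannot be read. The compounds shown leave open whether changing the aryl group or its chain alters the half-maximal cytotoxic concentration at all.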